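From difluorophenyl to dimethylphenyl on a sulfonamide nitrogen

The compounds below may be only part of what the source reports. "The series", "measured", "known", "first", "only" and "open" are said of these compounds alone.

Measured in a functional assay on HT-29 cells (Homo sapiens) for antiproliferative activity, read by sulforhodamine B assay, with a stated time of 48 h; on this read-out lower numbers stand for stronger inhibition and higher numbers for weaker inhibition:
Compound 1 `Cc1ccc(NS(=O)(=O)c2ccc(N3CCNC3=O)cc2)cc1`: 480 nM
Compound 2 `Cc1ccc(NS(=O)(=O)c2ccc(N3CCNC3=O)cc2)cc1C`: 230 nM
Compound 3 `O=C1NCCN1c1ccc(S(=O)(=O)Nc2ccc(F)c(F)c2)cc1`: 350 nM

Compound 3 gives 350 nM, and its gaps to the other two lie within the scatter: a 1.4-fold lower number from compound 1 to compound 3 (0.14 log units; within the scatter), and a 1.5-fold higher number from compound 2 to compound 3 (0.18 log units; within the scatter). Compound 4 `Cc1cc(C)cc(NS(=O)(=O)c2ccc(N3CCNC3=O)cc2)c1` carries 3,5-dimethylphenyl in place of 3,4-difluorophenyl on a sulfonamide nitrogen. The closest guide is the 3,4-dimethylphenyl of compound 2, where the same kind of swap gave a 1.5-fold higher number from compound 2 to compound 3 (0.18 log units; within the scatter). Adding one methyl gave a 2.1-fold lower number from compound 1 to compound 2 (0.32 log units; beyond the scatter), a modest step. No 3,5-dimethylphenyl compound has been measured yet, so only a small change is expected, not one beyond the scatter. The expected step is a 1.3-fold lower number from compound 3 to compound 4 (0.10 log units; within the scatter) in this assay. Compound 4 is estimated at 280 nM, with an expected range from 130 nM to 550 nM.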

Compound 4, half-maximal inhibitory concentration: 82 nM
Estimate against measurement, compound 4: 3.4-fold (0.53 log units) above; measured number below the stated range.
By their numbers in this assay, from the lowest: compound 4; then compounds 2, 3 and 1 (each within the scatter of the next, the first and the last beyond it).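

In this assay, moving the two methyls on the ring at the sulfonamide nitrogen matters: a 2.8-fold lower number from compound 2 to compound 4 (0.45 log units; beyond the scatter) shows that 3,5-dimethylphenyl and 3,4-dimethylphenyl, with the same atoms, are not interchangeable. Within the data shown here, the other two steps, a 4.3-fold lower number from compound 3 to compound 4 (0.63 log units; beyond the scatter) and a 5.9-fold lower number from compound 1 to compound 4 (0.77 log units; beyond the scatter), are also beyond the scatter and larger than any step among the earlier compounds. Nothing available explains why this arrangement gives the lowest number.

Still open, going by these compounds, is whether methyl itself is needed, which a 3,5-dichlorophenyl or 3,5-dimethoxyphenyl on the same nitrogen could test.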